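The source may report more compounds than this note shows. Statements on the series, on what has been measured and on what is new or still open speak of the compounds shown alone.

The series rests on one shared core: compound 1 `CC(C)C(c1ncc[nH]1)c1ccc(-c2ccc3cccc(F)c3c2)[nH]c1=O`, compound 2 `CC(C)C(c1nnc[nH]1)c1ccc(-c2ccc3cccc(F)c3c2)[nH]c1=O` and compound 3 `CC(C)C(c1ccc(-c2ccc3cccc(F)c3c2)[nH]c1=O)N1CCNC1=O` differ only in the group on a saturated chain carbon bound to an aromatic carbon and a saturated chain carbon. In a functional assay on CHO cells for antagonist activity at prostaglandin E2 receptor EP3 subtype (Homo sapiens), read by cAMP accumulation (a higher number here means a weaker inhibitor, a lower number a stronger inhibitor), compound 1 gives 33 nM, compound 2 gives 21 nM and compound 3 gives 28 nM. Compound 3 therefore stands second highest of the three numbers, nearest to compound 1 and furthest from compound 2, yet the steps of a 1.2-fold lower number from compound 1 to compound 3 (0.07 log units; within the scatter) and a 1.3-fold higher number from compound 2 to compound 3 (0.12 log units; within the scatter) both lie within the scatter, as does a 1.6-fold lower number from compound 1 to compound 2 (0.20 log units; within the scatter). The three groups tried at this place are thus not told apart by this assay.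

Compound 4 `CC(C)C(c1noc(=O)[nH]1)c1ccc(-c2ccc3cccc(F)c3c2)[nH]c1=O` is not yet measured. Against compound 3 the change is a group of 6 heavy atoms (2 carbon, 2 nitrogen, 2 oxygen; one five-membered aromatic ring with 3 hetero atoms) in place of a group of 6 heavy atoms (3 carbon, 2 nitrogen, 1 oxygen; one five-membered non-aromatic ring with 2 hetero atoms), on a saturated chain carbon bound to an aromatic carbon and a saturated chain carbon. Going by the values given here, the steps that bear on it are the two into the 2-oxoimidazolidin-1-yl group, a 1.2-fold lower number from compound 1 to compound 3 (0.07 log units; within the scatter) and a 1.3-fold higher number from compound 2 to compound 3 (0.12 log units; within the scatter), and the exchange of one five-membered ring for another, a 1.6-fold lower number from compound 1 to compound 2 (0.20 log units; within the scatter); none moved the number beyond the scatter. No step beyond the scatter is therefore expected in this assay, in either direction. Compound 4 is expected to give 30 nM, within 12 nM to 75 nM. The expected step amounts to a 1.1-fold higher number from compound 3 to compound 4 (0.03 log units; within the scatter).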

Compound 4, half-maximal inhibitory concentration: 41 nM
The estimate for compound 4 lay 1.4-fold (0.14 log units) below the measured number; the measured number falls inside the stated range.
By their numbers in this assay, from the lowest: compounds 2, 3, 1 and 4 (each within the scatter of the next).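

In this assay, the group entering in compound 4 cannot be told apart from the three groups before it: a 1.5-fold higher number from compound 3 to compound 4 (0.17 log units; within the scatter), a 2.0-fold higher number from compound 2 to compound 4 (0.29 log units; within the scatter) and a 1.2-fold higher number from compound 1 to compound 4 (0.09 log units; within the scatter). Going by these compounds alone, the earlier compounds covered only two aromatic rings and one non-aromatic ring, whereas this group keeps the six heavy atoms of the 2-oxoimidazolidin-1-yl group, swaps a non-aromatic ring for an aromatic one and carries more hydrogen-bond acceptors, and none of this gives a step beyond the scatter at this place on the saturated chain carbon. The four compounds therefore form one flat set at this position, and no information on the cause of that flatness is available.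

All four groups are five-membered rings holding nitrogen, so it remains open whether a carboxylic acid, a primary amine, an open-chain amide or a six-membered ring such as pyridin-2-yl would also leave the number within the scatter of these compounds. Going by these compounds, it also remains open whether a plain hydrogen at this place would do so, which would show whether the ring contributes to the number at all.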